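The compounds below may be only part of what the source reports. "The series", "measured", "known", "first", "only" and "open" are said of these compounds alone.

Compound 2 `O=S(=O)(c1ccccc1)n1c(-c2cn(-c3ccccc3)nc2-c2ccc(C(F)(F)F)cc2)nc2ccccc21` was tested in a functional assay on A549 cells (Homo sapiens) for antiproliferative activity, read by MTT assay, with a stated time of 24 h (on this read-out lower numbers stand for stronger inhibition and higher numbers for weaker inhibition), and gives 480 nM. Going by the values given here, the only other compound measured, compound 1 `Cc1ccc(-c2nn(-c3ccccc3)cc2-c2nc3ccccc3n2S(=O)(=O)c2ccccc2)cc1`, gives 760 nM in this assay, and the step of a 1.6-fold lower number from compound 1 to compound 2 (0.20 log units; within the scatter) lies within the scatter, so the two compounds cannot be told apart on these numbers. Compound 3 `O=S(=O)(c1ccc(Cl)cc1)n1c(-c2cn(-c3ccccc3)nc2-c2ccc(C(F)(F)F)cc2)nc2ccccc21` differs from compound 2 by chloro in place of hydrogen on an aromatic carbon. Among the compounds with values here, no measured step touches this part of the molecule, so nothing here points in either direction, and no step beyond the scatter is expected. Compound 3 is therefore estimated at 450 nM, within 150 nM to 1300 nM. That amounts to an expected step of a 1.1-fold lower number from compound 2 to compound 3 (0.03 log units; within the scatter).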

Compound 3, half-maximal inhibitory concentration: 2560 nM
The estimate for compound 3 lay 5.7-fold (0.76 log units) below the measured number, and the stated range ends below it.
By their numbers in this assay, from the lowest: compounds 2 and 1 (each within the scatter of the next); then compound 3.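

Going by these compounds alone, on the phenylsulfonyl group, which the earlier compounds left unchanged, replacing phenyl with 4-chlorophenyl in this assay gives a 5.3-fold higher number from compound 2 to compound 3 (0.73 log units; beyond the scatter) and so weakens inhibition beyond the scatter. This ring is therefore not indifferent to substitution, since a single chlorine atom para to a large group is enough to shift the result. No measurement available here accounts for this loss. From the compounds shown here alone, it remains open whether the loss is specific to chloro or would also follow from fluoro, methoxy or an amine at this position. Going by these compounds, whether chloro would have the same effect with methyl in place of trifluoromethyl also remains unknown.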